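Replacing 3,4-dimethoxyphenyl with 4-fluorophenyl on the shared core

The source may report more compounds than this note shows. Statements on the series, on what has been measured and on what is new or still open speak of the compounds shown alone.

In a functional assay on HepG2 cells (Homo sapiens) for antiproliferative activity, read by sulforhodamine B assay, with a stated time of 48 h (a higher number here means a weaker inhibitor, a lower number a stronger inhibitor), compound 1 `COc1ccc(/C=C/C(=O)c2ccccc2-c2ccc(OC)c(OC)c2)cc1OC` gives 3200 nM. Compound 2 `COc1ccc(OC)c(/C=C/C(=O)c2ccccc2-c2ccc(OC)c(OC)c2)c1` gives 2100 nM and compound 3 `COc1ccc(-c2ccccc2C(=O)/C=C/c2ccc(Br)cc2)cc1OC` gives 3300 nM, so compound 1 lies within the scatter of both. Compound 4 `COc1ccc(/C=C/C(=O)c2ccccc2-c2ccc(F)cc2)cc1OC` has not yet been measured. Its difference from compound 1 is 4-fluorophenyl in place of 3,4-dimethoxyphenyl on an aromatic carbon, with 4-fluorophenyl in place of 3,4-dimethoxyphenyl on an aromatic carbon, ortho to a large group. Within the data shown here, all three measured compounds carry 3,4-dimethoxyphenyl there, so no measured step tests this change directly. The available steps concern a group on a double-bonded chain carbon: a 1.5-fold lower number from compound 1 to compound 2 (0.18 log units; within the scatter), a 1.0-fold higher number from compound 1 to compound 3 (0.01 log units; within the scatter) and a 1.6-fold higher number from compound 2 to compound 3 (0.20 log units; within the scatter). All three stay within the scatter, but they offer only indirect guidance. With so little evidence, no shift beyond the scatter is expected, though the uncertainty is wide. The expected step is a 1.1-fold lower number from compound 1 to compound 4 (0.03 log units; within the scatter). Compound 4 is estimated at 3000 nM, with an expected range from 1200 nM to 7500 nM.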

Compound 4, half-maximal inhibitory concentration: 95 nM
Compound 4: middle estimate off by 32-fold (1.50 log units), on the high side; measured number below the stated range.
By their numbers in this assay, from the lowest: compound 4; then compounds 2, 1 and 3 (each within the scatter of the next).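

The aromatic carbon that carries 3,4-dimethoxyphenyl in compound 1 turns out to be highly sensitive: exchanging that group for 4-fluorophenyl gives a 34-fold lower number from compound 1 to compound 4 (1.53 log units; beyond the scatter) in this assay and yields a stronger inhibitor. The earlier steps, all at the double-bonded chain carbon, stayed within the scatter, so this is the first change shown to move the number beyond it. No measurement shown here accounts for the size of this step.

Because the exchange removes both methoxy groups and adds a fluorine in one step, the compounds shown cannot separate the contribution of each, and an unsubstituted phenyl, a 4-methoxyphenyl or a 4-chlorophenyl at this carbon would help to do so. As far as these compounds go, it also remains open whether 4-fluorophenyl has the same effect alongside 2,5-dimethoxyphenyl or 4-bromophenyl on the chain carbon.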